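Dithiocarbamate triazoles against a gastric carcinoma line

The source may report more compounds than this note shows. Statements on the series, on what has been measured and on what is new or still open speak of the compounds shown alone.

Measured so far:
compound 1 `CC(C)(C)OC(=O)N1CCN(C(=S)SCc2cn(-c3ccccc3F)nn2)CC1`: 119000 nM
compound 2 `Cc1cc(=O)oc2cc(OCCn3cc(CSC(=S)N4CCN(C(=O)OC(C)(C)C)CC4)nn3)ccc12`: 76900 nM

In a functional assay on MGC-803 cells (Homo sapiens) for inhibition, read by MTT assay, with a stated time of 72 h (on this read-out higher numbers stand for weaker inhibition and lower numbers for stronger inhibition), compound 1 gives 119000 nM, the highest of the two numbers shown. Compound 2 gives 76900 nM in this assay; the gap between compound 1 and compound 2 is within the scatter, so no order between them can be drawn.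

Compound 3 `CC(C)(C)OC(=O)N1CCN(C(=S)SCc2cn(Cc3ccccc3Cl)nn2)CC1` is not yet measured. It differs from compound 1 by 2-chlorobenzyl in place of 2-fluorophenyl on an aromatic nitrogen. Among the compounds with values here, no measured pair shows a change of this kind, so nothing here tells the size of its effect; a step no larger than the scatter is expected in either direction.

Compound 3 is therefore estimated at 100000 nM (range 40000 nM to 250000 nM), which is expected to mean a step of a 1.2-fold lower number from compound 1 to compound 3 (0.08 log units; within the scatter).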

Compound 3, half-maximal inhibitory concentration: 490 nM
Beside the measured number, compound 3's estimate is 200-fold (2.31 log units) above it; measured number outside the range, below it.
By their numbers in this assay, from the lowest: compound 3; then compounds 2 and 1 (each within the scatter of the next).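

In this assay, the step of a 240-fold lower number from compound 1 to compound 3 (2.39 log units; beyond the scatter) shows that the group on this aromatic nitrogen can move the read-out strongly, which the gap between compound 1 and compound 2, within the scatter, did not reveal. The change swaps fluorine for chlorine and phenyl for benzyl together, so the step cannot be divided between them. No measurement at hand accounts for the step.

Still open, going by these compounds, is whether 2-fluorobenzyl or 2-chlorophenyl would separate the two parts of the change. Also open, on these data alone, is how an unsubstituted benzyl or a longer 2-phenylethyl chain would read at this position.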